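The compounds below may be only part of what the source reports. "The series", "measured", "known", "first", "only" and "open" are said of these compounds alone.

Series notes. The compounds share one core, carried through compound 1, `Cc1c(O)ccc2c1[C@H](Cn1cc(-c3ccc(F)cc3)nn1)[C@@]13CC(=O)[C@@](C)(CC[C@@H]21)C3`, compound 2, `Cc1ccc(S(=O)(=O)Oc2ccc3c(c2C)[C@H](Cn2cc(-c4ccc(C(F)(F)F)cc4)nn2)[C@@]24CC(=O)[C@@](C)(CC[C@@H]32)C4)cc1`, and compound 3, `C=C1C[C@]23C[C@@]1(O)CC[C@@H]2c1cccc(C)c1[C@@H]3Cn1cc(-c2ccc(OC)cc2)nn1`, each read in a functional assay on SW480 cells (Homo sapiens) for cytotoxicity, read by MTT assay, with a stated time of 4 days; a higher number here means a weaker inhibitor, a lower number a stronger inhibitor. In this assay compound 1 gives > 20000 nM, which is a limit of the assay and not a number. In this assay compound 2 gives > 20000 nM, again a limit rather than a number. In this assay compound 3 gives > 20000 nM, also a limit. Going by the values given here, compound 2 therefore stands where every measured value stands, at the limit of > 20000 nM in this assay, at which 3 of the 3 values shown sit, and since no compound in the set has returned a number, no step between measured compounds can be sized.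

Compound 4, `Cc1ccc(S(=O)(=O)Oc2ccc3c(c2C)[C@H](Cn2cc(-c4ccc(F)cc4)nn2)[C@@]24CC(=O)[C@@](C)(CC[C@@H]32)C4)cc1`, is not yet measured in this assay. It differs from compound 2 in one place: fluoro in place of trifluoromethyl on an aromatic carbon. Compound 1 already carries 4-fluorophenyl on the triazole and sits at > 20000 nM, a limit. On that basis the expected step is a number no higher from compound 2 to compound 4 (the limit leaves the size open), none beyond the scatter, and the most likely outcome is that this assay returns only a limit once more. Compound 4 is expected to give 20000 nM in this assay, with a range from 8000 nM to 60000 nM.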

Compound 4, half-maximal inhibitory concentration: > 20000 nM
Compound 4 ended at the assay's limit; the forecaster's own chance of this, stated with the estimate: 85%; the middle value lies on the limit itself.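

In this assay compound 4 gives > 20000 nM, a limit of the assay and not a number. The steps to compound 4 from compound 2 and from compound 1 therefore cannot be read: the limit of > 20000 nM in this assay, at which 4 of the 4 values shown sit. The compounds shown leave open whether any change on the shared core returns a number in this assay, and how large such a step would be.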